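Working notes: from compound 3 to compound 4

A few compounds are considered here, and "the series" means these few. Any claim that something is new, unique, unknown or untested is made for them only; others in the source may bear on it.

Measured in an ADME assay on SH-SY5Y cells (Homo sapiens) for cytotoxicity, read by MTT assay, with a stated time of 48 h (on this read-out lower numbers stand for an effect already at smaller amounts and higher numbers for an effect only at larger amounts of compound), so far:
- compound 1 `NC(=O)c1ccccc1-c1ccccc1C(=O)NCCCCCCCn1cc(-c2cccnc2)nn1` gives 289 nM as a number
- compound 2 `O=C(O)c1cccc(-c2ccccc2C(=O)NCCCCCCCn2cc(-c3cccnc3)nn2)c1` gives > 500 nM as a limit
- compound 3 `O=C(NCCCCCCCn1cc(-c2cccnc2)nn1)c1ccccc1-n1cc(CN2CCC(O)CC2)nn1` gives > 10000 nM as a limit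

Compound 3 carries only the limit > 10000 nM and no number. Among the compounds with values here, compound 1 at 289 nM holds the only number among the three values.

Compound 4 `CC(C)N1CCN(Cc2cn(-c3ccccc3C(=O)NCCCCCCCn3cc(-c4cccnc4)nn3)nn2)CC1` is not yet measured. It carries 4-isopropylpiperazin-1-yl in place of 4-hydroxypiperidin-1-yl on a saturated chain carbon bound to an aromatic carbon and otherwise keeps the core of compound 3.

Within the data shown here, the one measured step (an at least 1.7-fold higher number from compound 1 to compound 2 (0.23 log units; that floor lies within the scatter)) is a different change, 3-carboxyphenyl in place of 2-carbamoylphenyl on an aromatic carbon. Among the measured compounds shown here, no measured step covers the saturated chain carbon, so its size carries over only loosely.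

The expectation rests mainly on compound 3 and its limit > 10000 nM as the closest structure. Compound 1 at 289 nM shows that numbers far lower do occur in the series. In this assay the estimated step is an at least 1.6-fold lower number from compound 3 to compound 4 (0.22 log units; that floor lies within the scatter) with wide uncertainty, and a second limit would be no surprise. The expected value for compound 4 is 6000 nM within 800 nM to 20000 nM in this range estimate.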

Compound 4, half-maximal effective concentration: > 10000 nM
Compound 4: a limit, no number (the forecaster's own chance of this, stated with the estimate: 45%); at least 1.6-fold (0.22 log units) between middle value and limit.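

In this assay compound 3 and compound 4 each give a limit and no number, so no step between them can be read, because both stand at the same limit: the limit of > 10000 nM in this assay, at which 2 of the 4 values shown sit.

The compounds shown leave open whether 4-isopropylpiperazin-1-yl in place of 4-hydroxypiperidin-1-yl changes the read-out at all, and in which direction.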